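The source may report more compounds than this note shows. Statements on the series, on what has been measured and on what is new or still open speak of the compounds shown alone.

Measured in an in vivo ADME assay on the whole organism for metabolic stability, with Mus musculus as the target, read by LC-MS, at a dose of 160 mg/kg by the oral route; on this read-out higher numbers stand for a longer-lived compound and lower numbers for a shorter-lived compound:
Compound 1, `CC(C)N1CC(=O)N=C1N/C(=N\C(C)(C)C)Nc1ccc(Cl)c(Cl)c1`: 0.0287 h
Compound 2, `CC(C)n1cc(OC(=O)C(C)(C)C)nc1N/C(=N\C(=O)C(C)(C)C)Nc1ccc(Cl)c(Cl)c1`: > 1 h, a limit of the assay

Going by the values given here, compound 1 holds the only plain number in this small set; in this assay compound 1 gives a half-life of 0.0287 h. For compound 2 the assay reports > 1 h, which is a limit of the assay and not a number, so that (the limit of > 1 h in this assay, at which 1 of the 2 values shown sits). Compound 3, `CC(C)N1CC(=O)N=C1N/C(=N\C(=O)OC(C)(C)C)Nc1ccc(Cl)c(Cl)c1`, has not yet been measured. It differs from compound 1 in one place: tert-butoxycarbonyl in place of tert-butyl on a double-bonded nitrogen. Among the compounds with values here, no pair of measured compounds differs in that single place, so no measured step tells the size of the change to expect. Compound 1 is very short-lived at 0.0287 h. On that basis a longer half-life for compound 3 is expected, and the step is estimated at a 3.5-fold higher number from compound 1 to compound 3 (0.54 log units; beyond the scatter). Compound 3 is accordingly expected to give about 0.1 h, with a range from 0.02 h to 1 h.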

Compound 3, half-life: 0.263 h
The estimate for compound 3 lay 2.6-fold (0.42 log units) below the measured number; the range from low to high includes it.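

In this assay, going by these compounds alone, the group on a double-bonded nitrogen proves to matter for the first time: with the rest of the core of compound 1 unchanged, tert-butoxycarbonyl in place of tert-butyl gives a 9.2-fold higher number from compound 1 to compound 3 (0.96 log units; beyond the scatter). Within the data shown here, this is the first comparison in the set that differs in one place, so a change at this position alone can be seen to lengthen the half-life in the whole animal, although this rests on a single pair and says nothing about why the half-life rises. Compound 2 differs from the others in more than one place and offers only a limit of the assay, not a number, so it adds no second step at this position: the limit of > 1 h in this assay, at which 1 of the 3 values shown sits.

One pair cannot separate the contribution of the added carbonyl from that of the added oxygen, or show whether the bulk of the tert-butyl portion plays any part. From the compounds shown here alone, it also remains open how a smaller methoxycarbonyl, an acetyl or a simple amine would behave on this nitrogen, and whether the same change would lengthen the half-life on a different core.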